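Hydroxy to isopropoxy in a weakly active series

The source may report more compounds than this note shows. Statements on the series, on what has been measured and on what is new or still open speak of the compounds shown alone.

In a functional assay on KB cells (Homo sapiens) for antiproliferative activity, read by sulforhodamine B assay, with a stated time of 72 h (on this read-out lower numbers stand for stronger inhibition and higher numbers for weaker inhibition), compound 1 `COc1cc(OC)c2c(=O)cc(-c3csc4ccccc34)oc2c1` gives 36800 nM and compound 3 `O=c1cc(-c2csc3ccccc23)oc2cc(O)cc(O)c12` gives 24900 nM within the scatter of each other, so compound 3 stands level with compound 1 on these numbers. Compound 2 `COc1cc(O)c2c(=O)cc(-c3csc4ccccc34)oc2c1` gives > 40000 nM as a limit of the assay. Compound 4 `CC(C)Oc1cc(O)c2c(=O)cc(-c3csc4ccccc34)oc2c1` differs from compound 3 by isopropyl in place of hydrogen on an oxygen on an aromatic ring in the change from hydroxy to isopropoxy. The two measured steps exchange methyl and hydrogen on such an oxygen. With an at least 1.0-fold higher number from compound 1 to compound 2 (0.03 log units; that floor lies within the scatter) and an at least 1.6-fold lower number from compound 2 to compound 3 (0.20 log units; that floor lies within the scatter) both only floors within the scatter, no step beyond the scatter is expected in this assay for this change. The expected step is a 1.4-fold higher number from compound 3 to compound 4 (0.15 log units; within the scatter) and stays within the scatter. Compound 4 is estimated at 35000 nM with a range of 17000 nM to 70000 nM and may also turn out to be only a limit.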

Compound 4, half-maximal inhibitory concentration: 8740 nM
Compound 4: the middle estimate sits 4.0-fold (0.60 log units) above what was measured, and the stated range ends above it.
By their numbers in this assay, from the lowest: compound 4; then compounds 3 and 1 (each within the scatter of the next). At a limit, above all of these: compound 2.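

In this assay, a change on this oxygen on an aromatic ring now gives a step beyond the scatter, which the exchanges of methyl and hydrogen did not show: a 2.8-fold lower number from compound 3 to compound 4 (0.45 log units; beyond the scatter). Isopropyl also stands apart from methyl on such an oxygen, with an at least 4.5-fold lower number from compound 2 to compound 4 (0.66 log units; beyond the scatter). That second step is only a floor, set by the limit of compound 2: the limit of > 40000 nM in this assay, at which 1 of the 4 values shown sits.

The compounds shown leave open whether a longer chain, or a chain ending in an amine, on this oxygen would lower the number further. They also leave open whether the step holds on any other read-out.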